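Replacing the Aromatic Ring with Cyclohexyl

A few compounds are considered here, and "the series" means these few. Any claim that something is new, unique, unknown or untested is made for them only; others in the source may bear on it.

In a functional assay, with a stated time of 30 min, in the absence of a further agent (on this read-out lower numbers stand for stronger inhibition and higher numbers for weaker inhibition), compound 2 `Cc1ccc(C(=O)Nc2nnc(-c3cccc(O)c3O)s2)cc1` gives 27100 nM and compound 1 `O=C(Nc1nnc(-c2cccc(O)c2O)s1)c1ccc(Cl)cc1` gives 30200 nM so the two stand level within the scatter. For the measured compounds named here, compound 3 `O=C(Nc1nnc(-c2cccc(O)c2O)s1)C1CCCCC1` keeps the shared core but carries cyclohexyl in place of 4-methylphenyl on a carbonyl carbon as its one structural change. Going by the values given here, only one measured step offers any guidance. The step of a 1.1-fold lower number from compound 1 to compound 2 (0.05 log units; within the scatter) exchanged a small group on the aromatic ring and left the ring itself in place. Among the compounds with values here, it therefore bears only loosely on compound 3, and no measurement yet tests the loss of that aromatic ring. On this thin evidence, no step beyond the scatter is expected in this assay and neither direction is favoured. The estimated change is a 1.1-fold higher number from compound 2 to compound 3 (0.04 log units; within the scatter) with wide uncertainty. For compound 3 the estimated value is 30000 nM with an expected range from 10000 nM to 90000 nM in this read-out.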

Compound 3, half-maximal inhibitory concentration: 19900 nM
Compound 3: middle estimate off by 1.5-fold (0.18 log units), on the high side; the range from low to high includes it.
By their numbers in this assay, from the lowest: compounds 3, 2 and 1 (each within the scatter of the next).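

In this assay, the change of the aromatic ring to a non-aromatic one on this carbonyl carbon gives a 1.4-fold lower number from compound 2 to compound 3 (0.13 log units; within the scatter), and the comparison with the chloro-substituted ring gives a 1.5-fold lower number from compound 1 to compound 3 (0.18 log units; within the scatter). The earlier step only exchanged a small group on the aromatic ring, whereas these steps show that, among the compounds shown, cyclohexyl stands level with both 4-methylphenyl and 4-chlorophenyl, so an aromatic ring is not required here to keep this level of inhibition. No available data bear on why the three compounds stand level.

As far as these compounds go, all three compounds carry a six-membered ring of carbon only at this place, so it remains open whether any ring is needed, which an open longer chain such as butyl would test. From the compounds shown here alone, it is also open whether a group of a different kind, such as an amine or a carboxylic acid on the ring, would move the number beyond the scatter.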